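A smaller group on the aryl oxygen: compound 4

A few compounds are considered here, and "the series" means these few. Any claim that something is new, unique, unknown or untested is made for them only; others in the source may bear on it.

Measured compounds:
compound 1 `CC(Oc1ccccc1Br)C1=NCCN1` 10 nM
compound 2 `CCc1ccccc1OC(C)C1=NCCN1` 100 nM
compound 3 `CC(Oc1ccccc1OC1CC1)C1=NCCN1` 47.9 nM

Among the three compounds measured in a functional assay on CHO cells for agonist activity at Alpha-2C adrenergic receptor (Homo sapiens) (a lower number here means that less compound is needed, a higher number that more compound is needed for the effect), compound 3 stands second highest, with compound 2 nearest and compound 1 furthest. The steps that end at compound 3 are both modest: a 4.8-fold higher number from compound 1 to compound 3 (0.68 log units; beyond the scatter) and a 2.1-fold lower number from compound 2 to compound 3 (0.32 log units; beyond the scatter).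

Compound 4 `COc1ccccc1OC(C)C1=NCCN1` is not yet measured. It differs from compound 3 by methyl in place of cyclopropyl on an oxygen on an aromatic ring. Among the compounds with values here, no measured step alters the group on this oxygen; the only step that touches the oxygen at all is a 2.1-fold lower number from compound 2 to compound 3 (0.32 log units; beyond the scatter), which exchanges a carbon substituent for the cyclopropyloxy group, and it says nothing about shortening the alkyl on that oxygen. Compound 1, with bromo, gives the lowest number, while the two compounds carrying larger groups at this position sit higher, so a smaller substituent may not hurt. The step from compound 3 to compound 4 is therefore expected to be small, within the scatter or slightly lower, namely a 1.2-fold lower number from compound 3 to compound 4 (0.08 log units; within the scatter). For compound 4 the estimate is 40 nM, within 15 nM to 120 nM.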

Compound 4, half-maximal effective concentration: 9770 nM
Compound 4: the middle estimate sits 240-fold (2.39 log units) below what was measured, outside the stated range (above it).
By their numbers in this assay, from the lowest: compound 1; then compound 3; then compound 2; then compound 4.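

In this assay, within the data shown here, the change from cyclopropyloxy to methoxy gives a 200-fold higher number from compound 3 to compound 4 (2.31 log units; beyond the scatter), so the group on this oxygen, which no earlier step had altered, counts for far more than the earlier steps at this position showed. Methoxy also stands far from ethyl and bromo on this aromatic carbon, with a 98-fold higher number from compound 2 to compound 4 (1.99 log units; beyond the scatter) and a 980-fold higher number from compound 1 to compound 4 (2.99 log units; beyond the scatter), which leaves compound 4 with the highest number of the four. Nothing in the data at hand accounts for this jump.

From the compounds shown here alone, it remains open whether the jump is peculiar to methyl or also extends to other groups on this oxygen; ethyl, isopropyl or cyclobutyl there would show whether a ring or a longer chain is what matters. Going by these compounds, it is equally open how a hydroxyl or a chlorine would fare on this aromatic carbon.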